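Microsomal stability notes: pruning the pyrrolidine amide

The compounds below may be only part of what the source reports. "The series", "measured", "known", "first", "only" and "open" are said of these compounds alone.

Measured so far:
compound 1 `COc1ccc(-c2c(C)nc3c(N4CC[C@@H](NC(C)=O)C4)cc(C)nn23)cc1OC` — > 95%
compound 2 `COc1ccc(-c2c(C)nc3c(N4CC[C@@H](NC(=O)Oc5ccc6ccccc6c5)C4)cc(C)nn23)cc1OC` — > 95%

In an ADME assay on microsomes from liver (Homo sapiens) for metabolic stability, read by LC-MS, with NADPH named in the record, with a stated time of 60 min, tested at 1 uM, in the absence of a further agent (on this read-out higher numbers stand for a more stable compound and lower numbers for a less stable compound), compound 1 gives > 95%; this is a limit of the assay, not a number. In this assay compound 2 likewise gives > 95%, again a limit. Among the compounds with values here, both values sit at the same ceiling (the limit of > 95% in this assay, at which 2 of the 2 values shown sit), so the one measured step, a step that the two limits leave unreadable from compound 1 to compound 2, cannot be read in either direction, and compound 1 can only be placed at or beyond that limit, not ranked against compound 2.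

Compound 3 `COc1ccc(-c2c(C)nc3c(N4CC=CC4)cc(C)nn23)cc1OC` is not yet measured in this assay. Against compound 1 it carries the change (a group of 5 heavy atoms (4 carbon, 1 nitrogen; one five-membered non-aromatic ring with 1 hetero atom) in place of a group of 9 heavy atoms (6 carbon, 2 nitrogen, 1 oxygen; one five-membered non-aromatic ring with 1 hetero atom), on an aromatic carbon). Within the data shown here, no measured step touches this change: the single step from compound 1 to compound 2 alters the carbonyl substituent of the acetamide, whereas here the whole 3-acetamidopyrrolidin-1-yl group is exchanged. The direction of the step therefore cannot be anchored on the numbers at hand, and a loss from the ceiling is as plausible as staying at it.

Compound 3 is expected to give 80%, within 45% to 97%. The expected step is a number at least 15 percentage points lower from compound 1 to compound 3 (beyond the scatter), with a fair chance that only a limit is again reported.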

Compound 3, percent of the compound remaining: > 95%
Compound 3 was reported as a limit; the forecaster's own chance of this, stated with the estimate: 40%; middle value at least 15 percentage points from the limit.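

In this assay compound 3 gives > 95%, a limit and not a number. Within the data shown here, no step among compound 1, compound 2 and compound 3 can be read, since all three share one ceiling: the limit of > 95% in this assay, at which 3 of the 3 values shown sit. The compounds shown leave open whether any of these changes alters stability in this assay at all, and by how much.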